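Removing one methoxy group from compound 3

This account rests on a few compounds, and the source may have more. Where it says the series, first, only, none or still open, it means among the compounds named here.

Compound 1 `COc1cc(OC)c(CCC(=O)CC(C)=O)c(OC)c1` gives 139000 nM
Compound 2 `CC(=O)CC(=O)CCc1ccc(O)cc1` gives 213000 nM
Compound 3 `COc1ccc(/C=C/C(=O)CC(C)=O)cc1OC` gives 4700 nM

All three numbers come from a functional assay on HCT-116 cells (Homo sapiens) for antiproliferative activity, read by MTT assay, with a stated time of 72 h (on this read-out lower numbers stand for stronger inhibition and higher numbers for weaker inhibition), and from no other test. Compound 3 has the lowest of them, and the values of compound 1 and compound 2 both lie beyond the scatter from it.

Still unmeasured is compound 4 `COc1ccc(/C=C/C(=O)CC(C)=O)cc1` which differs from compound 3 in one place: hydrogen in place of methoxy on an aromatic carbon. Going by the values given here, no two measured compounds differ in one place only, so the data give no direct size for this change.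

Compound 3 remains the reference at 4700 nM and compound 4 keeps the rest of its structure, so its number is expected to stay fairly close to that value, though probably somewhat higher, which would mean weaker inhibition. The expected change is a 1.9-fold higher number from compound 3 to compound 4 (0.28 log units; within the scatter) and it may not clear the scatter by much. In this assay compound 4 is estimated at 9000 nM with an expected range of 3000 nM to 30000 nM for this measurement.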

Compound 4, half-maximal inhibitory concentration: 11900 nM
Estimate against measurement, compound 4: 1.3-fold (0.12 log units) below; low and high end bracket the measured number.
By their numbers in this assay, from the lowest: compound 3; then compound 4; then compounds 1 and 2 (each within the scatter of the next).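

In this assay, replacing with hydrogen the methoxy group that stands ortho to a methoxy group and meta to a group of 8 heavy atoms gives a 2.5-fold higher number from compound 3 to compound 4 (0.40 log units; beyond the scatter), the first direct size for a single change in this set. The position is therefore not indifferent to what it carries, although the step is modest and the other methoxy group stays in place throughout. Nothing available here bears on why the number rises with this change.

Going by these compounds, it remains open whether fluorine or an amine on this aromatic carbon would give a number closer to that of methoxy or to that of hydrogen. Going by these compounds alone, also open is whether this exchange has the same size on the chain of compound 1, as no pair with that chain differs in this place alone.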